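The source may hold more compounds than are shown below. What is called first, only, known or untested is meant among the compounds shown, and "the series" means these compounds.

Compound 3 `COC(=O)c1c(C)cccc1OC(=O)COc1cc(O)c2c(=O)cc(-c3ccccc3)oc2c1` is an ester carrying a methyl on the aromatic ring. In an ADME assay on cells (T-cell, Mus musculus, strain BALB/c) for cytotoxicity, read by MTT assay, with a stated time of 48 h (a higher number here means that more compound is tolerated, a lower number that less compound is tolerated), compound 3 gives 298000 nM, and it cannot be separated within the scatter from compound 2 `COC(=O)c1ccc(Cl)cc1OC(=O)COc1cc(O)c2c(=O)cc(-c3ccccc3)oc2c1` at 265000 nM or compound 1 `COC(=O)c1cc(O)ccc1OC(=O)COc1cc(O)c2c(=O)cc(-c3ccccc3)oc2c1` at 263000 nM. The steps of a 1.0-fold higher number from compound 1 to compound 2 (0.00 log units; within the scatter), a 1.1-fold higher number from compound 1 to compound 3 (0.05 log units; within the scatter) and a 1.1-fold higher number from compound 2 to compound 3 (0.05 log units; within the scatter) all stay within the scatter, although each swaps a whole aromatic group on the oxygen next to the carbonyl. Compound 4 `COC(=O)c1ccccc1OC(=O)COc1cc(O)c2c(=O)cc(-c3ccccc3)oc2c1` differs from compound 3 by hydrogen in place of methyl on an aromatic carbon. All three measured steps bear on this change, since each also alters only the substituent on that ring, and none moved the number. The change to compound 4 is smaller still, so no step beyond the scatter is expected: a 1.1-fold lower number from compound 3 to compound 4 (0.03 log units; within the scatter). Compound 4 is estimated at 280000 nM, ranging from 180000 nM to 430000 nM.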

Compound 4, half-maximal cytotoxic concentration: 265000 nM
Compound 4: middle estimate off by 1.1-fold (0.02 log units), on the high side, and the stated range covers the measured number.
By their numbers in this assay, from the lowest: compounds 1, 2, 4 and 3 (each within the scatter of the next).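

With the unsubstituted ring of compound 4 as reference, each substituent can now be read against hydrogen on an aromatic carbon in this assay: methyl (a 1.1-fold lower number from compound 3 to compound 4 (0.05 log units; within the scatter)), chloro (no change at the digits printed from compound 2 to compound 4 (within the scatter)) and hydroxy (a 1.0-fold higher number from compound 1 to compound 4 (0.00 log units; within the scatter)). All three steps stay within the scatter, so in these four compounds, removing the substituent altogether does not separate the numbers any more than swapping one for another did. No measurement here offers an explanation for this flat response.

Still open, going by these compounds, is whether an amine or a carboxylic acid on this ring, or a longer chain in place of the methyl, would move the number. Changes to the shared core also remain open.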